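Methoxy in place of methyl on the shared core

The source may report more compounds than this note shows. Statements on the series, on what has been measured and on what is new or still open speak of the compounds shown alone.

Measured compounds in this set:
Compound 1 `Cc1ccc2c(NCc3ccco3)nc(NC(C)C)nc2c1` gives >= 30000 nM in a physicochemical assay for solubility, at pH 2; on this read-out higher numbers stand for higher solubility and lower numbers for lower solubility; this value is a limit of the assay, not a number.
Compound 2 `Cc1ccc2nc(NC(C)C)nc(NCc3ccco3)c2c1` gives >= 30000 nM in this assay; this too is a limit of the assay.
Compound 3 `COc1ccc2c(NCc3ccco3)nc(NC(C)C)nc2c1` gives >= 30000 nM in this assay; again a limit of the assay.

Compound 1 and compound 2 are built from the same atoms joined differently; the difference between the two cores is not broken down here. Compound 3 arises from compound 1 by one change, (methoxy in place of methyl on an aromatic carbon), and the resulting step in this assay is a step that the two limits leave unreadable from compound 1 to compound 3. Nothing further can be read from that pair because of the limit of >= 30000 nM in this assay, at which 3 of the 3 values shown sit.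

Compound 4 `COc1ccc2nc(NC(C)C)nc(NCc3ccco3)c2c1` has not yet been measured. It arises from compound 2 by methoxy in place of methyl on an aromatic carbon, the same change that leads from compound 1 to compound 3, the place of the change being described in identical words in both pairs. For compound 4 the expected step in this assay is a number no higher from compound 2 to compound 4 (the limit leaves the size open), set beside the measured step that the two limits leave unreadable from compound 1 to compound 3; this expectation rests on compound 1, compound 2 and compound 3 all standing at the limit noted in the limit of >= 30000 nM in this assay, at which 3 of the 3 values shown sit. Compound 4 is therefore estimated to give 30000 nM in this assay, most probably reported only as a limit rather than as a number, with the estimate spanning from 15000 nM to 60000 nM.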

Compound 4, solubility: >= 30000 nM
Compound 4 gave a limit, no number; the forecaster's own chance of this, stated with the estimate: 85%; the middle value lies on the limit itself.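

In this assay compound 4 gives >= 30000 nM, which is a limit of the assay and not a number. No new step can be read from compound 2 to compound 4 because both compounds stand at the same limit: the limit of >= 30000 nM in this assay, at which 4 of the 4 values shown sit.

The compounds shown leave open whether methoxy in place of methyl on an aromatic carbon moves the read-out in this assay at all, on either core.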